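The source may hold more compounds than are shown below. What is called first, only, known or untested is meant among the compounds shown, and "the series" means these compounds.

Of the compounds shown here, two sharing one core have been tested in an assay for inhibition of Nitric oxide synthase, inducible (Homo sapiens), read by scintillation counting, with a stated time of 30 min, tested at 1 mM; on this read-out higher numbers stand for more inhibition at the one concentration tested (going by the name of the read-out) and lower numbers for less inhibition. Compound 1 `CCNC(=O)NCCC(O)c1cc(OC)ccc1N` gives 26.6% in this assay. Compound 2 `CCCNC(=O)NCCC(O)c1cc(OC)ccc1N` gives 14.7% in this assay, the lower of the two numbers. Among the compounds with values here, the only measured step, a number 11.9 percentage points lower from compound 1 to compound 2 (beyond the scatter), is a lengthening of the chain on the same nitrogen that lowered the read-out. Compound 3 `COc1ccc(N)c(C(O)CCNC(=O)Nc2ccccc2)c1` has not yet been measured in this assay; it differs from compound 2 by phenyl in place of propyl on an amide-type nitrogen. Within the data shown here, no measured pair shows this kind of change, so the only guide is that a larger group on that nitrogen went with a lower number in the step from compound 1 to compound 2, and a phenyl is larger still. The step to compound 3 is therefore expected to be small or slightly downward, a number 2.7 percentage points lower from compound 2 to compound 3 (within the scatter), and compound 3 is estimated at 12%, between 0% and 40%.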

Compound 3, a percentage reported as inhibition, at one concentration (the size of the read-out at that concentration, not a potency): 12.3%
Compound 3: middle estimate off by 0.3 percentage points, on the low side; the range from low to high includes it.
By their numbers in this assay, from the lowest: compounds 3 and 2 (each within the scatter of the next); then compound 1.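

In this assay, phenyl in place of propyl on an amide-type nitrogen gives a number 2.4 percentage points lower from compound 2 to compound 3 (within the scatter) and so leaves the two compounds indistinguishable, which shows that at this position an aromatic ring and a three-carbon chain read alike. Phenyl in place of ethyl gives a number 14.3 percentage points lower from compound 1 to compound 3 (beyond the scatter) and so matches what propyl did: of the three groups tested on this nitrogen, only the ethyl of compound 1 stands apart from the others. Nothing measured here explains why the ethyl stands apart.

Still open, on these data alone, is whether a methyl or a plain hydrogen on this nitrogen would read above or below compound 1. As far as these compounds go, it is equally open whether a cyclohexyl ring, or a phenyl carrying a chlorine or a methoxy group, would read like compound 3.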